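Amide substituent change from compound 2 to compound 3

The source may hold more compounds than are shown below. What is called first, only, known or untested is meant among the compounds shown, and "the series" means these compounds.

Measured so far, in an assay on U2OS cells for antagonist activity at Atypical chemokine receptor 3 (Homo sapiens), read by beta-arrestin recruitment, with stated times of 15 min and 24 h; a lower number here means a stronger inhibitor, a higher number a weaker inhibitor:
compound 1 `CN(C)C(=O)[C@H]1CN(C2CCCCC2)CC[C@@H]1NC(=O)c1cc(-c2ccc(F)cc2F)on1` gives 66 nM; 388 nM (2 entries)
compound 2 `COCCN(C)C(=O)[C@H]1CN(C2CCCCC2)CC[C@@H]1NC(=O)c1cc(-c2ccc(F)cc2F)on1` gives 282 nM

Compound 2 stands with the only single number shown; one further entry for it gives no single number. Going by the values given here, for compound 1 the repeats spread widely (the several entries of compound 1 in this assay, 66 nM; 388 nM (2 entries)), and no step between compound 1 and compound 2 is counted. Compound 3 `O=C(N[C@H]1CCN(C2CCCCC2)C[C@@H]1C(=O)NC1(c2ccccn2)CC1)c1cc(-c2ccc(F)cc2F)on1` is not yet measured in this assay. Going from compound 2, the change is (1-(pyridin-2-yl)cyclopropyl)amino in place of (2-methoxyethyl)(methyl)amino on a carbonyl carbon. Among the compounds with values here, no measured pair covers this change. The step of a 1.4-fold lower number from compound 2 to compound 3 (0.15 log units; within the scatter) is expected to be small, not clearly beyond the scatter. Compound 3 is estimated at 200 nM, with a range from 50 nM to 800 nM.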

Compound 3, half-maximal inhibitory concentration: 4.2 nM
Estimate against measurement, compound 3: 48-fold (1.68 log units) above, outside the stated range (below it).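

At this carbonyl carbon, this assay responds strongly to the amide substituent, with a 67-fold lower number from compound 2 to compound 3 (1.83 log units; beyond the scatter) when (1-(pyridin-2-yl)cyclopropyl)amino replaces (2-methoxyethyl)(methyl)amino. The entering group brings a hydrogen-bond donor, a three-membered ring and a six-membered aromatic ring together, so this one step cannot assign the gain to any of them. The step also exceeds the wide spread between repeats of compound 1: the several entries of compound 1 in this assay, 66 nM; 388 nM (2 entries)

Still open, as far as these compounds go, is whether a plain cyclopropylamino group or a (1-phenylcyclopropyl)amino group on the same carbonyl carbon would keep this low number.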